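The source may hold more compounds than are shown below. What is called first, only, known or untested is meant among the compounds shown, and "the series" means these compounds.

Of the compounds shown here, two sharing one core have been measured. Compound 1 `O=C(CCCCCCc1ccccc1)c1ncc(-c2cccc(O)c2)o1` gives 50 nM in an assay (Rattus norvegicus) for inhibition of Fatty-acid amide hydrolase 1 (Homo sapiens); on this read-out higher numbers stand for weaker inhibition and lower numbers for stronger inhibition. Compound 2 `Nc1ccc(-c2cnc(C(=O)CCCCCCc3ccccc3)o2)cc1` carries a 4-aminophenyl group where compound 1 carries a 3-hydroxyphenyl group; in this assay compound 2 gives 90 nM. Going by the values given here, that is the higher of the two numbers known so far, but the only step, a 1.8-fold higher number from compound 1 to compound 2 (0.26 log units; within the scatter), lies within the scatter, so the two compounds cannot be told apart on this evidence.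

Compound 3 `O=C(CCCCCCc1ccccc1)c1ncc(-c2ccc(F)cc2)o1` is not yet measured. It differs from compound 2 by fluoro in place of amino on an aromatic carbon. Among the compounds with values here, the one measured step bears on it only loosely: swapping one small group on that ring for another moved the number little, as a 1.8-fold higher number from compound 1 to compound 2 (0.26 log units; within the scatter) shows. A similarly small shift is expected here, with no confident direction. The expected change is a 1.3-fold lower number from compound 2 to compound 3 (0.11 log units; within the scatter). Compound 3 is therefore estimated at 70 nM, with a range from 25 nM to 250 nM.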

Compound 3, inhibition constant: 62 nM
For compound 3 the middle estimate is 1.1-fold (0.05 log units) above the measured one; low and high end bracket the measured number.
By their numbers in this assay, from the lowest: compounds 1, 3 and 2 (each within the scatter of the next).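

In this assay, fluoro can stand where amino stood, para to a large group, with a step that stays within the scatter (a 1.5-fold lower number from compound 2 to compound 3 (0.16 log units; within the scatter)), although amino counts as a hydrogen-bond donor and acceptor and fluoro as neither. On this evidence, that difference in counts does not separate the two groups at this place, and 4-fluorophenyl in place of 3-hydroxyphenyl also stays within the scatter (a 1.2-fold higher number from compound 1 to compound 3 (0.09 log units; within the scatter)), so the three compounds cannot be told apart on this read-out. Nothing available explains why these numbers lie so close.

Still open, on these data alone, is whether a carboxylic acid or a trifluoromethyl group on that ring would give a step beyond the scatter. Also open, as far as these compounds go, is whether a longer chain on the carbonyl would matter more than these ring changes.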